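A few compounds are considered here, and "the series" means these few. Any claim that something is new, unique, unknown or untested is made for them only; others in the source may bear on it.

In a functional assay on U-251 cells (Homo sapiens) (on this read-out lower numbers stand for stronger inhibition of growth and higher numbers for weaker inhibition of growth), compound 2 (`O=S(=O)(/C=C/c1ccc(O)cc1)Cc1ccc(Nc2ncnc3ccc(Br)cc23)cc1`) gives > 100000 nM, which is a limit of the assay and not a number. Within the data shown here, compound 3 (`O=S(=O)(/C=C/c1ccc(Cl)cc1Cl)Cc1ccc(Nc2ncnc3ccc(Br)cc23)cc1`) gives 4000 nM, the only true number among the values shown. Among the measured compounds shown here, the remaining readings offer little more, since the series so far shows (the limit of > 100000 nM in this assay, at which 2 of the 3 values shown sit).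

Compound 4 (`O=S(=O)(/C=C/c1ccc(F)cc1F)Cc1ccc(Nc2ncnc3ccc(Br)cc23)cc1`) differs from compound 3 by 2,4-difluorophenyl in place of 2,4-dichlorophenyl on a double-bonded chain carbon bound to a double-bonded chain carbon. For the measured compounds named here, the one measured step at this place is an at least 25-fold lower number from compound 2 to compound 3 (1.39 log units; beyond the scatter), a large change beyond the scatter, so the group carried here can matter greatly. Compound 1 (`O=S(=O)(/C=C/c1ccc(F)cc1F)Cc1ccc(Nc2ncnc3ccccc23)cc1`) carries the same 2,4-difluorophenyl on a core of its own and gives > 100000 nM, again a limit. That reading, together with the size of the measured step, leads to the expectation of a moderate move toward weaker inhibition of growth. The expected change is a 3.8-fold higher number from compound 3 to compound 4 (0.57 log units; beyond the scatter). For compound 4 the estimated value is 15000 nM, with an expected range from 3000 nM to 80000 nM.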

Compound 4, concentration for 50% growth inhibition: 32000 nM
Compound 4: middle estimate off by 2.1-fold (0.33 log units), on the low side; measured number inside the range.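

At this place, the change from one halogen pair to the other is not neutral: in this assay there is an 8.0-fold higher number from compound 3 to compound 4 (0.90 log units; beyond the scatter), so 2,4-dichlorophenyl and 2,4-difluorophenyl are now separated by two true numbers. The 2,4-difluorophenyl group nonetheless improves on 4-hydroxyphenyl, with an at least 3.1-fold lower number from compound 2 to compound 4 (0.49 log units; beyond the scatter). The core also matters, as bromo in place of hydrogen on an aromatic carbon gives an at least 3.1-fold lower number from compound 1 to compound 4 (0.49 log units; beyond the scatter).

As far as these compounds go, the full size of these last two steps stays unknown, as each starts from a limit of the assay: the limit of > 100000 nM in this assay, at which 2 of the 4 values shown sit. From the compounds shown here alone, whether a 4-aminophenyl or 2,4-dibromophenyl group at this place would match compound 3 stays open, as does the size of the bromo effect with 2,4-dichlorophenyl in place.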